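A few compounds are considered here, and "the series" means these few. Any claim that something is new, unique, unknown or untested is made for them only; others in the source may bear on it.

In a functional assay on HCT-116 cells (Homo sapiens) for antiproliferative activity, read by MTT assay, with a stated time of 48 h (a lower number here means a stronger inhibitor, a higher number a weaker inhibitor), compound 1 (`CCC(CCO)n1cnc2c(Cl)nc(F)nc21`) gives 18900 nM while compound 2 (`CCCCCC(CCO)n1cnc2c(Cl)nc(F)nc21`) gives 8660 nM and compound 3 (`CCCCCCC(CCO)n1cnc2c(Cl)nc(F)nc21`) gives 9960 nM in the same read-out. Compound 3 stands within the scatter of both other compounds, with a 1.2-fold higher number from compound 2 to compound 3 (0.06 log units; within the scatter) and a 1.9-fold lower number from compound 1 to compound 3 (0.28 log units; within the scatter) as its two steps. Within the data shown here, only one step, a 2.2-fold lower number from compound 1 to compound 2 (0.34 log units; beyond the scatter) lies beyond the scatter, and it is modest.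

Compound 4 (`CCCCCCCCC(CCO)n1cnc2c(Cl)nc(F)nc21`) differs from compound 3 by one change on the same chain (ethyl in place of hydrogen on a saturated chain carbon, seven bonds along the chain from an aromatic nitrogen). The closest measured change is the methyl addition (a 1.2-fold higher number from compound 2 to compound 3 (0.06 log units; within the scatter)) which stayed within the scatter. The butyl change (a 1.9-fold lower number from compound 1 to compound 3 (0.28 log units; within the scatter)) also stayed within it. No step beyond the scatter is expected in this assay in either direction. The expected step is small (a 1.1-fold lower number from compound 3 to compound 4 (0.04 log units; within the scatter)) and rests on these few steps alone. Compound 4 is estimated at 9000 nM with an expected range from 4500 nM to 18000 nM for this estimate.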

Compound 4, half-maximal inhibitory concentration: 24200 nM
The estimate for compound 4 lay 2.7-fold (0.43 log units) below the measured number; measured number outside the range, above it.
By their numbers in this assay, from the lowest: compounds 2, 3, 1 and 4 (each within the scatter of the next, the first and the last beyond it).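

In this assay, lengthening the chain is no longer silent at this position: ethyl in place of hydrogen on a saturated chain carbon, seven bonds along the chain from an aromatic nitrogen, gives a 2.4-fold higher number from compound 3 to compound 4 (0.39 log units; beyond the scatter) and the propyl change six bonds along gives a 2.8-fold higher number from compound 2 to compound 4 (0.45 log units; beyond the scatter) while the earlier methyl change stayed within the scatter. The hexyl change three bonds along gives a 1.3-fold higher number from compound 1 to compound 4 (0.11 log units; within the scatter) so the modest gain seen with compound 2 does not persist in compound 4, and the number does not follow chain length in one direction across the four compounds. Nothing available explains this rise in the number.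

Open, on these data alone, is whether a longer chain raises the number further, and whether an amine or a phenyl group on this carbon would follow the alkyl chains.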